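A few compounds are considered here, and "the series" means these few. Any claim that something is new, unique, unknown or untested is made for them only; others in the source may bear on it.

Working notes on the series in a functional assay on SW480 cells (Homo sapiens) for cytotoxicity, read by MTT assay, with a stated time of 4 days; a lower number here means a stronger inhibitor, a higher number a weaker inhibitor.

Compound 1 `C=C1C[C@]23C[C@@]1(O)CC[C@@H]2c1cccc(C)c1[C@@H]3Cn1cc(-c2ccc(C)cc2)nn1` carries a 4-methylphenyl group at the outer end of the side chain on the shared core. In this assay compound 1 gives > 20000 nM, which is a limit of the assay and not a measured number. Compound 2 `Cc1c(O)ccc2c1[C@H](Cn1cc(-c3ccccn3)nn1)[C@@]13CC(=O)[C@@](C)(CC[C@@H]21)C3`, built on a different core and with a different aromatic group in the same part of the molecule, likewise gives only a limit, > 20000 nM, in this assay. Both values shown so far thus sit at the limit of > 20000 nM in this assay, at which 2 of the 2 values shown sit, so compound 1 stands nowhere that can be ranked: no number below the limit has been recorded for any member of the series.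

Compound 3 `C=C1C[C@]23C[C@@]1(O)CC[C@@H]2c1cccc(C)c1[C@@H]3Cn1cc(-c2ccc(C(F)(F)F)cc2)nn1` is the next analogue, differing from compound 1 as follows: trifluoromethyl in place of methyl on an aromatic carbon. Going by the values given here, no step between two measured compounds is available to calibrate this change, so there is nothing in the data to indicate a move in either direction. The expectation is therefore a step that the limit leaves unreadable from compound 1 to compound 3 in this assay, that is, none beyond the scatter. Compound 3 is expected to give about 25000 nM in this assay, within a range of 8000 nM to 80000 nM, most likely reported again as a limit.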

Compound 3, half-maximal inhibitory concentration: > 20000 nM
Compound 3 was reported as a limit; the forecaster's own chance of this, stated with the estimate: 75%; the middle value is on the limit's open side.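

In this assay compound 3 gives > 20000 nM, which is a limit and not a number; with compound 1 also reported only as a limit, no step can be read between compound 1 and compound 3. The compounds shown leave open whether trifluoromethyl in place of methyl changes the value at all, and how any member of the series ranks: the limit of > 20000 nM in this assay, at which 3 of the 3 values shown sit.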